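Taking one methyl off compound 3

The compounds below may be only part of what the source reports. "The series", "measured", "known", "first", "only" and "open" are said of these compounds alone.

Among the compounds with values here, in a physicochemical assay for solubility, at pH 6.8 (on this read-out lower numbers stand for lower solubility and higher numbers for higher solubility), compound 3 `Cc1c(COc2cccc(OCC3CCOCC3)c2)[nH]c2ccccc2c1=O` gives 5000 nM, the higher of the two true numbers so far. Compound 2 `COC(C)(C)CCOc1cccc(OCc2[nH]c3ccccc3c(=O)c2C)c1` gives 2000 nM, and the measured gap is a 2.5-fold higher number from compound 2 to compound 3 (0.40 log units; beyond the scatter). Compound 1 `CCCCOc1cccc(OCc2[nH]c3ccccc3c(=O)c2C)c1` gives < 1000 nM, which is a limit of the assay and not a number. Against that limit, the measured change is an at least 5.0-fold higher number from compound 1 to compound 3 (0.69 log units; beyond the scatter).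

Compound 4 `O=c1cc(COc2cccc(OCC3CCOCC3)c2)[nH]c2ccccc12` keeps the chain of compound 3 and has hydrogen in place of methyl on an aromatic carbon. Within the data shown here, no measured step touches this place, since all of them alter the chain on the oxygen. They therefore bear on it only loosely, as a guide to the size of step this series can show, and a 2.5-fold higher number from compound 2 to compound 3 (0.40 log units; beyond the scatter) is the closest yardstick. On that weak footing, a modest rise in this assay is expected. The expected change is a 2.4-fold higher number from compound 3 to compound 4 (0.38 log units; beyond the scatter). For compound 4 the estimate is 12000 nM, with an expected range from 3000 nM to 40000 nM.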

Compound 4, solubility: 4000 nM
Compound 4: middle estimate off by 3.0-fold (0.48 log units), on the high side; the measured number falls inside the stated range.
By their numbers in this assay, from the lowest: compounds 2, 4 and 3 (each within the scatter of the next, the first and the last beyond it). At a limit, below all of these: compound 1.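

On this aromatic carbon, hydrogen in place of methyl gives a 1.3-fold lower number from compound 3 to compound 4 (0.10 log units; within the scatter) in this assay, so this read-out does not separate the two compounds. Within the data shown here, this is the first measured step away from the chain on the oxygen, and it stays within the scatter, whereas a change of that chain gave a 2.5-fold higher number from compound 2 to compound 3 (0.40 log units; beyond the scatter). Nothing measured here accounts for the result at this position.

Going by these compounds, it remains open whether a different group on the same carbon, such as an amine, a methoxy group or a chlorine atom, would give a number that stands clear of the scatter. On these data alone, it also remains open whether hydrogen in place of methyl would give a similar result with the chains of compound 1 and compound 2.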